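Series notes: benzimidazole acids against protein kinase C zeta

This account rests on a few compounds, and the source may have more. Where it says the series, first, only, none or still open, it means among the compounds named here.

Compound 3 `O=C(O)CC(Cc1nc2cc(Cl)ccc2[nH]1)c1ccc(Cl)c(F)c1` in an assay on isolated protein for inhibition of protein kinase C zeta type (Homo sapiens), read by 33P incorporation, tested at 50 uM (a lower number here means a weaker effect, a higher number a stronger effect of the compound at the concentration tested), gives 0%. This is level with compound 1 `O=C(O)CC(Cc1nc2cc(Cl)ccc2[nH]1)c1ccc(Cl)cc1`, which gives 0%, the two together the lowest of the three numbers; compound 2 `O=C(O)CC(Cc1nc2cc(Br)ccc2[nH]1)c1ccc(Cl)cc1` gives 25%, with a number 25 percentage points higher from compound 1 to compound 2 (beyond the scatter). Compound 4 `O=C(O)CC(Cc1nc2cc(Cl)ccc2[nH]1)c1cccc(Cl)c1` differs from compound 3 by 3-chlorophenyl in place of 4-chloro-3-fluorophenyl on a saturated chain carbon bound to two saturated chain carbons. Among the compounds with values here, only one measured step touches this ring, no change at the digits printed from compound 1 to compound 3 (within the scatter), and no measured pair moves the chlorine on it; the data for this change are thin. Compound 3 and compound 1 both sit at the floor of this assay. For compound 4 the expected step is a number 5 percentage points higher from compound 3 to compound 4 (within the scatter), that is, none beyond the scatter. The estimate for compound 4 in this assay is therefore 5%, within 0% to 20%.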

Compound 4, a percentage reported as inhibition, at one concentration (the size of the read-out at that concentration, not a potency): 0%
Beside the measured number, compound 4's estimate is 5 percentage points above it; the range from low to high includes it.
By their numbers in this assay, from the lowest: compounds 1, 3 and 4 (each within the scatter of the next); then compound 2.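

In this assay, within the data shown here, the move to 3-chlorophenyl gives no change at the digits printed from compound 3 to compound 4 (within the scatter) and also no change at the digits printed from compound 1 to compound 4 (within the scatter), the first measured steps that shift the chlorine on this ring or remove the fluoro from it. With the chloro on the shared core, all three rings sit at the floor, so the read-out separates none of them. No available evidence bears on this result.

From the compounds shown here alone, whether 3-chlorophenyl reads differently alongside the bromo of compound 2 stays open. So does the effect of a methoxy or an amine on this ring.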